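Alkynyl branched-chain nucleosides: but-1-yn-1-yl to prop-1-yn-1-yl

The compounds below may be only part of what the source reports. "The series", "measured", "known", "first", "only" and "open" are said of these compounds alone.

Measured so far in a functional assay on L1210 cells (Mus musculus), read by MTT assay; a lower number here means a stronger inhibitor, a higher number a weaker inhibitor:
compound 1, `C#CC[C@@]1(O)[C@@H](CO)O[C@@H](n2ccc(=O)[nH]c2=O)[C@@H]1O`, reports only a limit, > 350000 nM.
compound 2, `CCC#C[C@@]1(O)[C@@H](CO)O[C@@H](n2ccc(=O)[nH]c2=O)[C@@H]1O`, gives 338000 nM.
compound 3, `C#C[C@]1(O)[C@@H](CO)O[C@@H](n2ccc(=O)[nH]c2=O)[C@@H]1O`, has several entries, > 350000 nM; 130 nM (2 entries).
compound 4, `CC#C[C@@]1(O)[C@@H](CO)O[C@@H](n2ccc(=O)[nH]c2=O)[C@@H]1O`, is not yet measured.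

Among the compounds with values here, compound 2 holds the only single number in this assay; one further value is a limit, and one further entry has no single number. Within the data shown here, the one measured step, an at least 1.0-fold lower number from compound 1 to compound 2 (0.01 log units; that floor lies within the scatter), lies within the scatter. Compound 3, the ethynyl analogue, is marked by the several entries of compound 3 in this assay, > 350000 nM; 130 nM (2 entries), so its entries disagree with each other, while compound 1 sits at the limit of > 350000 nM in this assay, at which 1 of the 3 values shown sits.

Compound 4 differs from compound 2 by hydrogen in place of methyl on a saturated chain carbon bound to a triple-bonded carbon. Among the measured compounds shown here, no measured step shares this change, so the expectation rests on compound 3, whose two numbered entries in the several entries of compound 3 in this assay, > 350000 nM; 130 nM (2 entries) sit far below the value of compound 2. Compound 4 is therefore expected to give a lower number than compound 2, a step of about a 17-fold lower number from compound 2 to compound 4 (1.23 log units; beyond the scatter), but with wide uncertainty. The estimate for compound 4 is 20000 nM, expected between 300 nM and 350000 nM.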

Compound 4, half-maximal inhibitory concentration: 354000 nM
The estimate for compound 4 lay 18-fold (1.25 log units) below the measured number, outside the stated range (above it).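

In this assay, within the data shown here, the first readable step for this change, hydrogen in place of methyl on a saturated chain carbon bound to a triple-bonded carbon, lies within the scatter: a 1.0-fold higher number from compound 2 to compound 4 (0.02 log units; within the scatter). Compound 2 and compound 4 therefore cannot be told apart, and but-1-yn-1-yl and prop-1-yn-1-yl read alike at this position on the shared core. Compound 1 gives only a limit, > 350000 nM, so its step to compound 4 cannot be read.

On these data alone, it remains open whether the ethynyl group of compound 3 reads differently from these two alkynes, as that compound's entries disagree with each other: the several entries of compound 3 in this assay, > 350000 nM; 130 nM (2 entries). Also open, as far as these compounds go, is how a longer chain on the alkyne, or an amine at its end, would read in this assay.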